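The source may hold more compounds than are shown below. What is called first, only, known or untested is meant among the compounds shown, and "the series" means these compounds.

Of the compounds shown here, two have been measured in an ADME assay for acid dissociation; on this read-out higher numbers stand for higher potency (the scale is a negative logarithm) and lower numbers for lower potency. Compound 1, with the structure `COc1cc(C(=O)O)ccc1Cc1cn(C)c2ccc(NC(=O)OC3CCCC3)cc12`, gives 7.84 in this assay. Compound 2, with the structure `CCCn1cc(Cc2ccc(C(=O)NS(=O)(=O)c3ccccc3)cc2OC)c2cc(NC(=O)OC3CCCC3)ccc21`, gives 8.44 in this assay, the higher of the two numbers, and its lead over compound 1 is beyond the usual scatter. The two compounds differ in more than one place, so their gap cannot be tied to a single change.

Compound 3, with the structure `COc1cc(C(=O)NS(=O)(=O)c2ccccc2)ccc1Cc1cn(C)c2ccc(NC(=O)OC3CCCC3)cc12`, has not yet been measured. It departs from compound 2 by one change: hydrogen in place of ethyl on a saturated chain carbon bound to an aromatic nitrogen. Going by the values given here, no measured pair shows this change on its own, so nothing firm is known about its effect. A small step is expected, the estimated move from compound 2 to compound 3 being a number 0.24 log units lower from compound 2 to compound 3 (within the scatter), within the scatter. Compound 3 is therefore estimated at 8.2 in this assay, with a likely range from 7.6 to 8.8.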

Compound 3, negative logarithm of the antagonist equilibrium constant: 9.69
Compound 3: the middle estimate sits 1.49 log units below what was measured; measured number outside the range, above it.
By their numbers in this assay, from the lowest: compound 1; then compound 2; then compound 3.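

Shortening the chain on the aromatic nitrogen from propyl to methyl gives a number 1.25 log units higher from compound 2 to compound 3 (beyond the scatter) in this assay, so this position is far from neutral, and the shorter chain is the better of the two shown. On the same core with the methyl chain, (phenylsulfonyl)amino in place of hydroxy on a carbonyl carbon gives a number 1.85 log units higher from compound 1 to compound 3 (beyond the scatter), which shows that this second single change also carries a large step. No independent measurement bears on the reason for either step.

An ethyl or butyl chain on that nitrogen would show whether the number falls steadily with chain length or changes abruptly. A propyl compound carrying the carboxylic acid, or a methylsulfonyl group in place of the phenylsulfonyl group, would test whether the two changes act independently and whether the phenyl ring is needed.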